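A few compounds are considered here, and "the series" means these few. Any claim that something is new, unique, unknown or untested is made for them only; others in the source may bear on it.

In a functional assay, tested at 200 ug/mL (a higher number here means a weaker effect of the compound at the concentration tested, a lower number a stronger effect), compound 1 `CCOC(=O)C1=C(C)N(c2ccccc2)C=CC1c1ccccc1` gives -34%. Compound 2 `CCOC(=O)C1=C(C)N(c2ccc(C)cc2)C=CC1c1ccccc1` gives -35.8% in this assay, and with a number 1.8 percentage points lower from compound 1 to compound 2 (within the scatter) it stands alongside compound 1, the two not separable by this measurement. Compound 3 `CCOC(=O)C1=C(C)N(c2ccc(F)cc2)C=CC1c1ccccc1` differs from compound 2 by fluoro in place of methyl on an aromatic carbon, at the same aromatic carbon where compound 1 and compound 2 already differ. Going by the values given here, the only step measured at that place, a number 1.8 percentage points lower from compound 1 to compound 2 (within the scatter), stayed inside the scatter, so a similarly small shift is expected here. Compound 3 is therefore estimated at -34%, ranging from -50% to -18%, an expected step of a number 1.8 percentage points higher from compound 2 to compound 3 (within the scatter).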

Compound 3, a percentage reported as activity, at one concentration (the size of the read-out at that concentration, not a potency): -42.5%
For compound 3 the middle estimate is 8.5 percentage points above the measured one, and the stated range covers the measured number.
By their numbers in this assay, from the lowest: compounds 3, 2 and 1 (each within the scatter of the next).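

At this aromatic carbon, para to a large group, fluoro now joins hydrogen and methyl, and this assay cannot separate the three: the swap of methyl for fluoro gives (a number 6.7 percentage points lower from compound 2 to compound 3 (within the scatter)) and the swap of hydrogen for fluoro gives (a number 8.5 percentage points lower from compound 1 to compound 3 (within the scatter)). Even a change to a different kind of atom leaves the read-out inside the usual scatter. No measurement here offers an explanation for these small steps.

Going by these compounds, whether an amine, a carboxylic acid or a longer chain at this carbon would move the read-out beyond the scatter remains open. Also open, on these data alone, is whether other carbons of this ring would respond in the same way.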